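The source may hold more compounds than are shown below. What is called first, only, known or untested is meant among the compounds shown, and "the series" means these compounds.

Three analogues of this series have numbers in a functional assay on MIA PaCa-2 cells (Homo sapiens) for cytotoxicity, read by luminescence, with a stated time of 72 h; a lower number here means a stronger inhibitor, a higher number a weaker inhibitor. Compound 1 `CN(C)C(=S)NN=Cc1ncc(F)c2ccccc12` gives 274 nM there. Compound 2 `CNC(=S)NN=Cc1nccc2c(N)cccc12` gives 11200 nM. Compound 3 `CNC(=S)N/N=C/c1nccc2ccccc12` gives 18700 nM. On these three numbers compound 2 stands second highest: its nearest neighbour is compound 3, whose number lies within the usual scatter of it, so no order between the two can be read; its furthest is compound 1, whose number lies far lower and beyond the scatter. For the measured compounds named here, no pair among the measured compounds differs in only one place, so no single-change step is known within the set.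

Compound 4 `CNC(=S)NN=Cc1nccc2c(NC)cccc12` has not been measured. It differs from compound 2 by methyl in place of hydrogen on a nitrogen on an aromatic ring. Going by the values given here, nothing among the measured compounds shows what this particular change does, so the expectation rests on the size of the change alone: a single carbon added to the aromatic amine. The step from compound 2 to compound 4 in this assay is expected to be small, a 1.1-fold lower number from compound 2 to compound 4 (0.05 log units; within the scatter), in no clear direction and not beyond the scatter. Compound 4 is therefore estimated at 10000 nM, with a range from 4000 nM to 28000 nM.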

Compound 4, concentration for 90% inhibition: 4240 nM
The estimate for compound 4 lay 2.4-fold (0.37 log units) above the measured number; the measured number falls inside the stated range.
By their numbers in this assay, from the lowest: compound 1; then compound 4; then compounds 2 and 3 (each within the scatter of the next).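

For the compounds shown here, on the amine of the shared core, methyl in place of hydrogen gives the first single-change step: in this assay the change reads a 2.6-fold lower number from compound 2 to compound 4 (0.42 log units; beyond the scatter) and this modest step lies beyond the scatter. The nitrogen on the aromatic ring therefore does not tolerate change silently, as a single added carbon there shifts the number towards a stronger inhibitor. Nothing on hand bears on why the step has this size or direction.

Going by these compounds, whether a longer chain such as ethyl, or an acetyl group, on this nitrogen extends the step or reverses it remains open, as does the effect of dimethylamino, which leaves no hydrogen on the nitrogen. On these data alone, compound 4 differs from compound 1 in more than one place, so how this step relates to the other changes also remains open.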